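This account rests on a few compounds, and the source may have more. Where it says the series, first, only, none or still open, it means among the compounds named here.

Values measured in a functional assay (thoracic aorta) for inhibition, with Rattus norvegicus as the target; a higher number here means a weaker inhibitor, a lower number a stronger inhibitor:
Compound 1 `CC(C)c1ccc2c(CCCCNS(=O)(=O)c3ccccc3)cc(C(=O)O)c-2cc1`: 70 nM
Compound 2 `CC(C)c1ccc2c(CCCCNS(=O)(=O)c3ccc(Cl)cc3)cc(C(=O)O)c-2cc1`: 5.3 nM
Compound 3 `CC(C)c1ccc2c(CCCCNS(=O)(=O)c3ccc(F)cc3)cc(C(=O)O)c-2cc1`: 11 nM

Compound 3 holds the middle number of the three. The gaps around it are a 2.1-fold higher number from compound 2 to compound 3 (0.32 log units; beyond the scatter) and a 6.4-fold lower number from compound 1 to compound 3 (0.80 log units; beyond the scatter).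

The next compound, compound 4 `CC(C)c1ccc2c(CCCCNS(=O)(=O)c3cccc(C(F)(F)F)c3)cc(C(=O)O)c-2cc1`, keeps the shared core and has 3-(trifluoromethyl)phenyl in place of 4-fluorophenyl on a sulfonyl sulfur.

Two measured steps put a group on this same aromatic ring in place of hydrogen. One, with chloro, was large: a 13-fold lower number from compound 1 to compound 2 (1.12 log units; beyond the scatter). The other, with fluoro, was modest: a 6.4-fold lower number from compound 1 to compound 3 (0.80 log units; beyond the scatter). Within the data shown here, no measured compound carries trifluoromethyl, so these steps offer only a rough guide. Both substituted compounds gave lower numbers than the unsubstituted one, so compound 4 is expected to stay near compound 3 at 11 nM rather than return towards compound 1 at 70 nM.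

The expected change is small, a 1.4-fold higher number from compound 3 to compound 4 (0.13 log units; within the scatter), and would lie within the scatter. For compound 4 the estimated value is 15 nM, with an expected range of 4 nM to 60 nM.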

Compound 4, half-maximal inhibitory concentration: 1600 nM
For compound 4 the middle estimate is 110-fold (2.03 log units) below the measured one; measured number outside the range, above it.
By their numbers in this assay, from the lowest: compound 2; then compound 3; then compound 1; then compound 4.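

A group on this aromatic ring does not always give a lower number: trifluoromethyl in place of hydrogen gives a 23-fold higher number from compound 1 to compound 4 (1.36 log units; beyond the scatter), the opposite direction to chloro and fluoro in compound 2 and compound 3. The steps from the other two substituted compounds are larger still, at a 150-fold higher number from compound 3 to compound 4 (2.16 log units; beyond the scatter) and a 300-fold higher number from compound 2 to compound 4 (2.48 log units; beyond the scatter), but each changes both the group and where the name places it, going from 4-fluorophenyl or 4-chlorophenyl to 3-(trifluoromethyl)phenyl. No measurement here gives a reason for this reversal.

Trifluoromethyl appears only in 3-(trifluoromethyl)phenyl, and chloro and fluoro only in 4-chlorophenyl and 4-fluorophenyl, so the effect of the group cannot be separated from the effect of its place on the ring. From the compounds shown here alone, how a methoxy or nitrile group on this ring would compare also remains open.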